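Oxazole aryl swap in the piperidine amide series

The compounds below may be only part of what the source reports. "The series", "measured", "known", "first", "only" and "open" are said of these compounds alone.

Compound 1 `CC[C@@H]1C[C@H](CC)CN(CCCNC(=O)C2CCN(Cc3nc(-c4ccccc4C)oc3C)CC2)C1`: 1270 10^-6 cm/s
Compound 2 `Cc1oc(-c2c(Cl)cccc2Cl)nc1CN1CCC(C(=O)NCCCN2C[C@H](C)C[C@H](C)C2)CC1`: "not determined" (no result reported)
Compound 3 `Cc1ccccc1-c1nc(CN2CCC(C(=O)NCCCN3CCCC(CC(C)C)C3)CC2)c(C)o1`: 3 10^-6 cm/s

In a physicochemical assay for permeability, using PAMPA (on this read-out higher numbers stand for higher permeability and lower numbers for lower permeability), compound 1 gives 1270 10^-6 cm/s and compound 3 gives 3 10^-6 cm/s, while compound 2 gives "not determined" (no result reported), so compound 2 stands nowhere on the numbers shown. Among the measured compounds shown here, the single measured step, a 420-fold lower number from compound 1 to compound 3 (2.63 log units; beyond the scatter), changes the saturated ring at the chain end and not the aryl on the five-membered ring. Compound 4 `Cc1ccc(-c2nc(CN3CCC(C(=O)NCCCN4C[C@H](C)C[C@H](C)C4)CC3)c(C)o2)c(C)c1` differs from compound 2 by 2,4-dimethylphenyl in place of 2,6-dichlorophenyl on an aromatic carbon. For the measured compounds named here, no measured step touches this place, so no size or direction beyond the scatter can be expected for it; the only anchor is the wide spread between compound 1 at 1270 10^-6 cm/s and compound 3 at 3 10^-6 cm/s. Compound 4 is therefore expected, with low confidence, to give about 150 10^-6 cm/s in this assay, within 8 10^-6 cm/s to 1200 10^-6 cm/s.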

Compound 4, apparent permeability: 353 10^-6 cm/s
Estimate against measurement, compound 4: 2.4-fold (0.37 log units) below; low and high end bracket the measured number.
By their numbers in this assay, from the lowest: compound 3; then compound 4; then compound 1.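

Among the compounds shown here, no new step can be read: compound 2 carries no number in this assay and so compound 4 at 353 10^-6 cm/s has no partner for a step. No evidence bears on this result. Still open, from the compounds shown here alone, is how 2,4-dimethylphenyl and 2,6-dichlorophenyl compare in this assay on the shared core.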